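A few compounds are considered here, and "the series" means these few. Any claim that something is new, unique, unknown or untested is made for them only; others in the source may bear on it.

Measured so far:
- compound 1 `O=C(C=C1CCN(C(=O)c2ccccc2O)CC1)N[C@@H]1CCN(Cc2ccc3cc(F)ccc3c2)C1`: < 64 mL/min/kg
- compound 2 `COc1ccc(C(=O)N2CCC(=CC(=O)N[C@@H]3CCN(Cc4ccc5cc(F)ccc5c4)C3)CC2)c(O)c1`: 232 mL/min/kg
- compound 3 `COc1ccc(C(=O)N2CCC(=CC(=O)N[C@@H]3CCN(Cc4ccc5cc(F)ccc5c4)C3)CC2)cc1OC`: 246 mL/min/kg

In an in vitro ADME assay on microsomes from liver (Homo sapiens) for metabolic stability (on this read-out lower numbers stand for slow clearance and higher numbers for fast clearance), compound 1 gives only a limit, < 64 mL/min/kg. Compound 1 stands at the limit of < 64 mL/min/kg in this assay, at which 1 of the 3 values shown sits, and so has no fixed number of its own. Compound 2 gives 232 mL/min/kg and compound 3 gives 246 mL/min/kg. Compound 4 `O=C(C=C1CCN(C(=O)c2cccc(F)c2)CC1)N[C@@H]1CCN(Cc2ccc3cc(F)ccc3c2)C1` differs from compound 1 by 3-fluorophenyl in place of 2-hydroxyphenyl on a carbonyl carbon. Two measured steps start from compound 1: an at least 3.6-fold higher number from compound 1 to compound 2 (0.55 log units; beyond the scatter) and an at least 3.8-fold higher number from compound 1 to compound 3 (0.58 log units; beyond the scatter); both alter the 2-hydroxyphenyl and both end well above the limit. Between the two methoxy-bearing analogues, a 1.1-fold higher number from compound 2 to compound 3 (0.03 log units; within the scatter), so they sit together. A rise of comparable size is therefore expected for compound 4, an at least 2.5-fold higher number from compound 1 to compound 4 (0.39 log units; beyond the scatter), the starting point being only a limit. Compound 4 is estimated at 160 mL/min/kg, between 60 mL/min/kg and 350 mL/min/kg.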

Compound 4, clearance: 459 mL/min/kg
Compound 4: the middle estimate sits 2.9-fold (0.46 log units) below what was measured; the whole stated range lies below it.
By their numbers in this assay, from the lowest: compounds 2, 3 and 4 (each within the scatter of the next). At a limit, below all of these: compound 1.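

In this assay compound 1 gives only a limit, < 64 mL/min/kg. The 3-fluorophenyl ring carries no methoxy, yet the change on the carbonyl carbon gives an at least 7.1-fold higher number from compound 1 to compound 4 (0.85 log units; beyond the scatter), so the rise seen with the earlier analogues does not require methoxy. The methoxy-bearing analogues are not separated from this compound, with a 1.9-fold higher number from compound 3 to compound 4 (0.27 log units; within the scatter) and a 2.0-fold higher number from compound 2 to compound 4 (0.30 log units; within the scatter). Still open, from the compounds shown here alone, is how far compound 1 lies under its limit. Also open, going by these compounds, is whether an unsubstituted phenyl or an aminophenyl on the carbonyl carbon would stay near compound 1 or group with compounds 2, 3 and 4.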